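From a Cyclopropyl Amide to a Propyl Carbamate

The source may report more compounds than this note shows. Statements on the series, on what has been measured and on what is new or still open speak of the compounds shown alone.

Compound 1 `O=C(Nc1ccc2nc(NC(=O)C3CCCCC3)sc2c1)c1cccc(F)c1` gives 0.64 ug/mL in a functional assay on WI-38 VA13 cells (Homo sapiens) for cytotoxicity; on this read-out lower numbers stand for an effect already at smaller amounts and higher numbers for an effect only at larger amounts of compound.
Compound 2 `O=C(Nc1ccc2nc(NC(=O)C3CC3)sc2c1)c1c(Cl)cccc1Cl` gives 0.013 ug/mL in this assay.

Compound 2 holds the lowest of the two numbers; compound 1 sits at a higher number, and that gap lies beyond the scatter. Compound 3 `CCCOC(=O)Nc1nc2ccc(NC(=O)c3c(Cl)cccc3Cl)cc2s1` is not yet measured. It differs from compound 2 in a single place: propoxy in place of cyclopropyl on a carbonyl carbon. Among the measured compounds shown here, no measured pair shows this change, so there is nothing here to anchor its direction. A modest shift toward higher numbers is expected, a 2.3-fold higher number from compound 2 to compound 3 (0.36 log units; beyond the scatter). For compound 3 the estimated value is 0.03 ug/mL, with a range from 0.006 ug/mL to 0.2 ug/mL.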

Compound 3, half-maximal effective concentration: 0.0025 ug/mL
Beside the measured number, compound 3's estimate is 12-fold (1.08 log units) above it; measured number outside the range, below it.
By their numbers in this assay, from the lowest: compound 3; then compound 2; then compound 1.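

Putting propoxy in place of cyclopropyl on this carbonyl carbon gives a 5.2-fold lower number from compound 2 to compound 3 (0.72 log units; beyond the scatter) in this assay, so the change moves the effect to smaller amounts of compound. This is the first pair shown that differs in one place, and it shows that the three-membered ring is not needed here for a low number. The compounds shown leave open whether the shift belongs to the added oxygen or to the open chain, and whether a butyl or a butoxy group would do the same. Nothing measured here explains the shift.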